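Benzylsulfanyl to butylsulfanyl on the shared core

This account rests on a few compounds, and the source may have more. Where it says the series, first, only, none or still open, it means among the compounds named here.

Compound 1 `Nc1nc(SCc2ccccc2)nc2c1nc(O)n2Cc1ccccc1` gives 0.1 uM in a functional assay (spleen, spleen) for activation, with Mus musculus as the target (on this read-out higher numbers stand for an effect only at larger amounts of compound and lower numbers for an effect already at smaller amounts), the lowest of the two numbers shown. Compound 2 `COc1cccc(Cn2c(O)nc3c(N)ncnc32)c1` gives 10 uM in this assay, a gap from compound 1 that lies beyond the scatter. Compound 3 `NNc1nc2c(N)ncnc2n1Cc1ccccc1` is recorded in this assay as a limit, > 10 uM, not as a number; it sits at the limit of > 10 uM in this assay, at which 1 of the 3 values shown sits. Going by the values given here, no step between two measured compounds that differ in one place is available, so the step to compound 4 rests on compound 1 alone. Compound 4 `CCCCSc1nc(N)c2nc(O)n(Cc3ccccc3)c2n1` differs from compound 1 by propyl in place of phenyl on a saturated chain carbon bound to a sulfur, benzylsulfanyl to butylsulfanyl. A modest weakening is expected, a 3.0-fold higher number from compound 1 to compound 4 (0.48 log units; beyond the scatter). Compound 4 is expected to give 0.3 uM in this assay, within 0.05 uM to 3 uM.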

Compound 4, minimum effective concentration: 0.01 uM
The estimate for compound 4 lay 30-fold (1.48 log units) above the measured number; measured number outside the range, below it.
By their numbers in this assay, from the lowest: compound 4; then compound 1; then compound 2.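

In this assay the change from benzylsulfanyl to butylsulfanyl gives a 10-fold lower number from compound 1 to compound 4 (1.00 log units; beyond the scatter) and so the phenyl ring on this saturated chain carbon bound to a sulfur is not required for a low number. Propyl, with no ring, does better at this place than phenyl, though this rests on a single pair. Nothing measured here bears on why the change acts in this direction.

On these data alone, it remains open whether a longer chain such as hexyl would hold or lower the number further. As far as these compounds go, it also remains open how a butyl chain ending in an amine or a carboxylic acid would read.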